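A few compounds are considered here, and "the series" means these few. Any claim that something is new, unique, unknown or untested is made for them only; others in the source may bear on it.

Measured so far:
compound 1 `CC1CCN(c2c(S(=O)(=O)c3cc(Cl)cc(Cl)c3)cnc3c(F)cccc23)CC1` gives 82%;
compound 2 `CC1CCN(c2c(S(=O)(=O)c3ccc(Cl)c(Cl)c3)cnc3ccc(Cl)cc23)CC1` gives 86%;
compound 3 `COc1ccc2ncc(S(=O)(=O)c3ccc(Cl)c(Cl)c3)c(N3CCC(C)CC3)c2c1` gives 87%.

All three numbers come from an assay on isolated protein for displacement of a labelled ligand from metabotropic glutamate receptor 5 (Homo sapiens), with a stated time of 60 min, tested at 1 uM; a higher number here means more inhibition at the concentration tested (going by the name of the read-out), a lower number less inhibition. On these numbers compound 2 sits between the other two, and all three lie within the scatter of one another, so none can be called stronger or weaker. For the measured compounds named here, the one measured single-point step, a number 1 percentage points higher from compound 2 to compound 3 (within the scatter), changed a group on the core and was within the scatter. Compound 4 `CC1CCN(c2c(S(=O)(=O)c3ccc(F)c(F)c3)cnc3ccc(Cl)cc23)CC1` differs from compound 2 only in this: 3,4-difluorophenyl in place of 3,4-dichlorophenyl on a sulfonyl sulfur. Going by the values given here, no measured step touches the group on the sulfonyl sulfur, so there is nothing to lean on directly. Replacing both chlorines by fluorines is a modest change, and a small drop is expected, a number 8 percentage points lower from compound 2 to compound 4 (within the scatter), possibly just beyond the scatter. Compound 4 is therefore estimated at 78%, between 55% and 93%.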

Compound 4, a percentage reported as inhibition, at one concentration (the size of the read-out at that concentration, not a potency): 72%
Estimate against measurement, compound 4: 6 percentage points above; the measured number falls inside the stated range.
By their numbers in this assay, from the lowest: compounds 4, 1, 2 and 3 (each within the scatter of the next, the first and the last beyond it).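

In this assay, for the compounds shown here, the group on the sulfonyl sulfur proves to count: 3,4-difluorophenyl in place of 3,4-dichlorophenyl gives a number 14 percentage points lower from compound 2 to compound 4 (beyond the scatter) and is the first single change here to go beyond the scatter. Going by these compounds alone, the earlier step, on the core, stayed within it, so this position is the more sensitive of the two so far, on one step each. The data offer no explanation for the drop. As far as these compounds go, how a plain phenyl, a 3,4-dimethylphenyl or a pyridine ring would fare on the sulfonyl sulfur remains open. So does whether changing only one of the two chlorines would be enough to lower the number.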